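A few compounds are considered here, and "the series" means these few. Any claim that something is new, unique, unknown or untested is made for them only; others in the source may bear on it.

Working notes on the series. Compound 1, `O=C(O)c1cn(-c2ccccc2)nc1-c1ccsc1`, carries a free acid on the carbonyl carbon. In a functional assay on HL-60 cells (Homo sapiens) for inhibition, read by MTT assay, with a stated time of 48 h (on this read-out lower numbers stand for stronger inhibition and higher numbers for weaker inhibition), compound 1 gives > 100000 nM, which is a limit of the assay and not a measured number. Compound 2, `O=C(NCc1ccccc1)c1cn(-c2ccccc2)nc1-c1ccsc1`, carries a benzylamino group in place of the hydroxy on that carbonyl carbon. In this assay compound 2 gives > 100000 nM, again a limit rather than a number. The step that the two limits leave unreadable from compound 1 to compound 2 therefore cannot be read in size. Both values shown sit at the same limit, (the limit of > 100000 nM in this assay, at which 2 of the 2 values shown sit), so compound 2 stands only at a limit and nowhere on a numerical scale.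

Compound 3, `COc1ccc(OC(=O)c2cn(-c3ccccc3)nc2-c2ccsc2)cc1`, differs from compound 2 by 4-methoxyphenoxy in place of benzylamino on a carbonyl carbon. Among the compounds with values here, the only measured step, from compound 1 to compound 2, is unreadable, and it changes the same carbonyl carbon; no step of readable size bears on the change to compound 3. No direction or size of step in this assay can be expected from the data, beyond the expectation that compound 3 will most likely also sit at the limit. The estimate for compound 3 is 150000 nM, within 30000 nM to 600000 nM, and the estimated step that the limit leaves unreadable from compound 2 to compound 3 is expected to be unreadable in the same way.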

Compound 3, half-maximal inhibitory concentration: > 100000 nM
Compound 3: only a limit was reported; the forecaster's own chance of this, stated with the estimate: 80%; the middle value lies beyond the limit too.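

In this assay compound 3 gives > 100000 nM as a limit and not a number. No new step can be read among compound 1, compound 2 and compound 3: the limit of > 100000 nM in this assay, at which 3 of the 3 values shown sit. The compounds shown leave open whether any group on this carbonyl carbon gives a measurable value in this assay and how large a step between such groups would be.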